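Working notes: hydrogen in place of methyl in compound 1

This account rests on a few compounds, and the source may have more. Where it says the series, first, only, none or still open, it means among the compounds named here.

- compound 1 `COc1ccc2c(c1)CCCN2c1nc(C)nc2ccccc12`: 2.5 nM
- compound 2 `CSc1ccc(N(C)c2nc(C)nc3ccccc23)cc1`: 2.9 nM

In a functional assay on A-431 cells (Homo sapiens) for cytotoxicity, read by sulforhodamine B assay (a higher number here means a weaker inhibitor, a lower number a stronger inhibitor), compound 1 gives 2.5 nM and compound 2 gives 2.9 nM. These two values lie within the scatter of each other, so compound 1 stands level with compound 2 and the pair sets no order.

Still unmeasured is compound 3 `COc1ccc2c(c1)CCCN2c1ncnc2ccccc12`. It differs from compound 1 by hydrogen in place of methyl on an aromatic carbon, between two ring nitrogen atoms.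

Going by the values given here, no measured pair isolates this change. Compound 1 and compound 2 both carry the methyl, and the data give no direct size for the step. In this assay a moderate step towards a higher number, meaning a weaker inhibitor, is expected. It would probably lie beyond the scatter, though a step within the scatter cannot be excluded.

For compound 3 the expected value is 12 nM, with an estimated range of 3 nM to 60 nM. This estimate means an expected 4.8-fold higher number from compound 1 to compound 3 (0.68 log units; beyond the scatter).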

Compound 3, half-maximal inhibitory concentration: 16.3 nM
For compound 3 the middle estimate is 1.4-fold (0.13 log units) below the measured one, within the range that was stated.
By their numbers in this assay, from the lowest: compounds 1 and 2 (each within the scatter of the next); then compound 3.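

The methyl on the aromatic carbon between two ring nitrogen atoms now has a measured size: in this assay, hydrogen in its place gives a 6.5-fold higher number from compound 1 to compound 3 (0.81 log units; beyond the scatter). This position is therefore not indifferent to its substituent, and of the two groups seen there, methyl gives the stronger inhibitor, although that reading rests on a single matched pair in one background. The data offer no measurement that accounts for the size of this step, so it stands as an observation without an assigned cause.

Going by these compounds, it remains open whether anything at this carbon improves on methyl: an ethyl group, a longer chain, a chlorine atom or an amine could each hold, raise or lower the number, and only such groups would show how much room the position allows. Compound 2 also carries the methyl but has no hydrogen partner among the compounds shown, so whether the same step holds in that background also remains open.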